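This account rests on a few compounds, and the source may have more. Where it says the series, first, only, none or still open, it means among the compounds named here.

Measured compounds:
compound 1 `CN(C)C(=O)OCCC1=C(N2CC2)C(=O)C(CCOC(=O)N(C)C)=C(N2CC2)C1=O` gives 4.62 in a functional assay on L1210 cells (Mus musculus), with a stated time of 1 days; a lower number here means a less potent compound, a higher number a more potent compound, by a factor of ten per unit of this negative logarithm;
compound 2 `CCC(OC)C1=C(N2CC2)C(=O)C(C)=C(N2CC2)C1=O` gives 4.84 in this assay;
compound 3 `CC(C)C1=C(N2CC2)C(=O)C(C(C)C)=C(N2CC2)C1=O` gives 4.14 in this assay.

Compound 2 holds the highest of the three numbers. Compound 1 sits within the scatter of it, so no order between those two is claimed; compound 3 lies lower by a step beyond the scatter.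

Compound 4 `CC1=C(N2CC2)C(=O)C(CCCOC(N)=O)=C(N2CC2)C1=O` is not yet measured. It differs from compound 2 as follows: a group of 7 heavy atoms (4 carbon, 1 nitrogen, 2 oxygen; no ring) in place of a group of 5 heavy atoms (4 carbon, 1 oxygen; no ring), on a double-bonded ring carbon.

Going by the values given here, no step between measured compounds with this single change is at hand. Compound 1, which carries two carbamate-bearing chains, gives 4.62, close to compound 2. The step of a number 0.14 log units lower from compound 2 to compound 4 (within the scatter) is therefore expected to be small, downward if anything, and within the scatter. For compound 4 the estimate in this assay is 4.7, with a range from 4.2 to 5.2.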

Compound 4, logarithm of the reciprocal of the active concentration, log(1/C): 5.48
Compound 4: middle estimate off by 0.78 log units, on the low side; the measured number lies above the stated range.
By their numbers in this assay, from the lowest: compound 3; then compounds 1 and 2 (each within the scatter of the next); then compound 4.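

In this assay the position on a double-bonded ring carbon, next to the ring atom that bears an aziridin-1-yl group, gives a real response to its substituent: the carbamate-ending chain in place of 1-methoxypropyl gives a number 0.64 log units higher from compound 2 to compound 4 (beyond the scatter). This change adds a hydrogen-bond donor and keeps the group free of rings, and the number still rises. Nothing available accounts for the rise. Open, on these data alone, is whether the carbamate or the chain carries the step, as a plain propyl group, a 3-hydroxypropyl chain or a longer chain ending in an amine could show.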